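Swapping Isopropyl for Cyclopentyl on an Amide Nitrogen

The source may hold more compounds than are shown below. What is called first, only, known or untested is meant among the compounds shown, and "the series" means these compounds.

Of the compounds shown here, three have been tested in a functional assay on BT-474 cells (Homo sapiens) for inhibition; on this read-out higher numbers stand for weaker inhibition and lower numbers for stronger inhibition. Compound 1 `COc1c(C)cnc(CN2CC(=O)N(C(C)C)c3c(Cl)nc(N)nc32)c1C` gives 30 nM, the lowest number of the three and thus the strongest inhibitor among them. For the measured compounds named here, compound 2 `COc1c(C)cnc(CN2c3nc(N)nc(Cl)c3NC(=O)[C@@H]2C)c1C` gives 470 nM, and compound 3 `COc1c(C)cnc(CN2c3nc(N)nc(Cl)c3NC(=O)[C@@H]2CC(C)C)c1C` gives 490 nM; the only single-point step measured, a 1.0-fold higher number from compound 2 to compound 3 (0.02 log units; within the scatter), concerns a different part of the molecule. Compound 4 `COc1c(C)cnc(CN2CC(=O)N(C3CCCC3)c3c(Cl)nc(N)nc32)c1C` is compound 1 with one change: cyclopentyl in place of isopropyl on an amide-type nitrogen in a ring. Going by the values given here, no measured step bears on this swap, so the expectation rests on compound 1 alone. The expected change is no change at the digits printed from compound 1 to compound 4 (within the scatter), within the scatter. Compound 4 is therefore estimated at 30 nM, with a range from 10 nM to 90 nM.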

Compound 4, half-maximal inhibitory concentration: 290 nM
Estimate against measurement, compound 4: 9.7-fold (0.99 log units) below; measured number above the stated range.
By their numbers in this assay, from the lowest: compound 1; then compounds 4, 2 and 3 (each within the scatter of the next).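

This position on the amide-type nitrogen proves sensitive to its group: going from isopropyl, with 3 heavy atoms, to cyclopentyl, with 5 heavy atoms and a ring, gives a 9.7-fold higher number from compound 1 to compound 4 (0.99 log units; beyond the scatter) in this assay and weakens inhibition. Neither group has hydrogen-bond donors, hydrogen-bond acceptors or a net charge, so those counts do not separate them. Nothing measured here gives a cause for this drop.

Going by these compounds, whether a methyl, a cyclopropyl or a tert-butyl on this nitrogen would keep the inhibition of the isopropyl group remains open.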